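A few compounds are considered here, and "the series" means these few. Any claim that something is new, unique, unknown or untested is made for them only; others in the source may bear on it.

Measured so far in a functional assay on the whole organism (strain Wistar) for inhibition, with Rattus norvegicus as the target, read by paw edema, with a stated time of 6 h, at a dose of 100 mg/kg; a lower number here means less inhibition, a higher number more inhibition at the dose given (going by the name of the read-out):
compound 1 `COc1cc2c(cc1OC)C(CC(=O)O)CC2` gives 20.4%
compound 2 `COc1cc2c(cc1OC)C(CC(=O)Nc1ccc(Cl)cc1)CC2` gives 61.1%
compound 3 `COc1ccccc1NC(=O)CC1CCc2cc(OC)c(OC)cc21` gives 24.1%

Compound 3 stands second of the three numbers; its value and that of compound 1 lie within the scatter of each other, whereas the step of a number 37 percentage points lower from compound 2 to compound 3 (beyond the scatter) is large. Compound 4 `COc1cc2c(cc1OC)C(CC(=O)Nc1ccncc1)CC2` differs from compound 3 in one place: pyridin-4-yl in place of 2-methoxyphenyl on an amide-type nitrogen. Both measured steps concern the same amide position. The steps of a number 40.7 percentage points higher from compound 1 to compound 2 (beyond the scatter) and a number 37 percentage points lower from compound 2 to compound 3 (beyond the scatter) show that what sits on the amide-type nitrogen moves this assay strongly, in either direction. Among the measured compounds shown here, no measured compound carries a pyridin-4-yl group, so the direction for compound 4 is uncertain; a moderate rise is expected, a number 10.9 percentage points higher from compound 3 to compound 4 (beyond the scatter). Compound 4 is estimated at 35%, with a range of 15% to 60%.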

Compound 4, a percentage reported as inhibition, in the whole organism at one dose (the size of the read-out at that dose, not a potency): 46.3%
For compound 4 the middle estimate is 11.3 percentage points below the measured one; the measured number falls inside the stated range.
By their numbers in this assay, from the lowest: compounds 1 and 3 (each within the scatter of the next); then compound 4; then compound 2.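

In this assay, a number 22.2 percentage points higher from compound 3 to compound 4 (beyond the scatter) and a number 14.8 percentage points lower from compound 2 to compound 4 (beyond the scatter) set the pyridin-4-yl amide apart from both aryl amides, so this position supports an intermediate level as well as the two extremes. With a number 25.9 percentage points higher from compound 1 to compound 4 (beyond the scatter), a second amide now stands clear of the acid, while compound 3 goes against any general gain from amide formation, as its value lies within the scatter of compound 1. No measurement on hand accounts for these differences.

Open, going by these compounds, is how a pyridin-3-yl group on the amide-type nitrogen would compare, and whether a piperidine amide or a longer chain between that nitrogen and the ring would hold the number.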